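Swapping Chloro for Methoxy on the Anilino Ring

The source may report more compounds than this note shows. Statements on the series, on what has been measured and on what is new or still open speak of the compounds shown alone.

Compound 1 `C#CCSc1nc(Nc2ccccc2Cl)c2ccncc2n1`: in a functional assay on PC-3 cells (Homo sapiens) for inhibition, read by MTT assay, with a stated time of 72 h (on this read-out higher numbers stand for weaker inhibition and lower numbers for stronger inhibition), compound 1 gives > 80000 nM, which is a limit of the assay and not a number.
Compound 2 `C#CCSc1nc(Nc2cccc(Cl)c2)c2ccncc2n1`: compound 2 gives 56500 nM.
Compound 3 `C#CCSc1nc(Nc2ccccc2OC)c2ccncc2n1`: compound 3 gives > 80000 nM, again only a limit of the assay.

The cores of compound 1 and compound 2 differ by 3-chlorophenyl in place of 2-chlorophenyl on a nitrogen on an aromatic ring, and the measured step is an at least 1.4-fold lower number from compound 1 to compound 2 (0.15 log units; that floor lies within the scatter). From compound 1 to compound 3 the change is methoxy in place of chloro on an aromatic carbon; its step is a step that the two limits leave unreadable from compound 1 to compound 3, since compound 3 sits at the limit of > 80000 nM in this assay, at which 2 of the 3 values shown sit.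

Compound 4 `C#CCSc1nc(Nc2cccc(OC)c2)c2ccncc2n1` is not yet measured. It differs from compound 2 by methoxy in place of chloro on an aromatic carbon, the same kind of change as from compound 1 to compound 3, but there the methoxy entered ortho to a large group and here it enters meta to a large group. The step from compound 2 to compound 4 in this assay is expected to be a 1.3-fold higher number from compound 2 to compound 4 (0.12 log units; within the scatter). That expectation rests on compound 2 at 56500 nM and on compound 3 sitting at the limit of > 80000 nM in this assay, at which 2 of the 3 values shown sit. Compound 4 is expected to give 75000 nM, likely between 30000 nM and 200000 nM, and may well return only a limit.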

Compound 4, half-maximal inhibitory concentration: 17100 nM
Compound 4: the middle estimate sits 4.4-fold (0.64 log units) above what was measured; measured number below the stated range.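

Methoxy in place of chloro, meta to a large group, brings a 3.3-fold lower number from compound 2 to compound 4 (0.52 log units; beyond the scatter) in this assay and thus stronger inhibition on this one core. The same change from compound 1 to compound 3 cannot be read, because both compounds sit at a limit of the assay and not at a number: the limit of > 80000 nM in this assay, at which 2 of the 4 values shown sit.
The step therefore shows what the change does on the core of compound 2, but it does not show that the gain carries over to the core of compound 1.

From the compounds shown here alone, it remains open whether a longer chain such as ethoxy would extend the gain seen with methoxy. Going by these compounds, it is equally open how an amine or a carboxylic acid would behave in that same place.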